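Bromophenyl Amide Expected to Recover Ground Lost by Hydroxyphenyl

This account rests on a few compounds, and the source may have more. Where it says the series, first, only, none or still open, it means among the compounds named here.

For the measured compounds named here, compound 3 `CN(C)C(=O)c1cc2cnc(Nc3ccc(NC(=O)C4(C(=O)Nc5cccc(O)c5)CC4)cc3)nc2n1C1CCCC1` gives 77.5% in a functional assay on NCI-H1299 cells (Homo sapiens) for inhibition, read by CCK-8 assay, with a stated time of 72 h, tested at 1 uM (a higher number here means more inhibition of growth at the concentration tested, a lower number less inhibition of growth), the second highest of the three numbers so far. Compound 1 `CN(C)C(=O)c1cc2cnc(Nc3ccc(NC(=O)C4(C(=O)Nc5ccc(F)cc5)CC4)cc3)nc2n1C1CCCC1` gives 93.3% in this assay, while compound 2 `CN(C)C(=O)c1cc2cnc(Nc3ccc(N)cn3)nc2n1C1CCCC1` gives 60.1%. Compound 4 `CN(C)C(=O)c1cc2cnc(Nc3ccc(NC(=O)C4(C(=O)Nc5ccc(Br)cc5)CC4)cc3)nc2n1C1CCCC1` remains unmeasured; its change from compound 3 is 4-bromophenyl in place of 3-hydroxyphenyl on an amide-type nitrogen. Going by the values given here, the one measured step that bears on it is a number 15.8 percentage points lower from compound 1 to compound 3 (beyond the scatter), and compound 4 reverses that kind of swap, replacing the hydroxyphenyl amide with a halogenated phenyl as in compound 1. A modest rise beyond the scatter is therefore expected, a number 12.5 percentage points higher from compound 3 to compound 4 (beyond the scatter). Compound 4 is estimated at 90% in this assay, within a range of 78% to 97%.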

Compound 4, percent growth inhibition at one concentration: 27.6%
Estimate against measurement, compound 4: 62.4 percentage points above; measured number below the stated range.
By their numbers in this assay, from the lowest: compound 4; then compound 2; then compound 3; then compound 1.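

In this assay, the halogen on this phenyl amide is not interchangeable: bromo in place of fluoro on an aromatic carbon gives a number 65.7 percentage points lower from compound 1 to compound 4 (beyond the scatter), a large step that the fluoro and hydroxy compounds alone gave no sign of. 4-bromophenyl in place of 3-hydroxyphenyl on the amide-type nitrogen likewise gives a number 49.9 percentage points lower from compound 3 to compound 4 (beyond the scatter), so a halogenated phenyl here does not by itself carry high growth inhibition. Nothing available explains this large difference between the two halogens.

The compounds shown leave open how a chloro or a methoxy group in place of the bromo on that aromatic carbon would read in this assay, and so whether the steep loss is particular to bromo.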